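Swapping the tail of compound 3

The compounds below may be only part of what the source reports. "The series", "measured", "known", "first", "only" and "open" are said of these compounds alone.

In a functional assay on HeLa cells (Homo sapiens) for inhibition, read by MTT assay, with a stated time of 4 days (a lower number here means a stronger inhibitor, a higher number a weaker inhibitor), these values stand
- compound 1 `COc1cc(NC(C)CCCNC(=O)NNC(=O)Nc2ccc(Cl)c(C(F)(F)F)c2)c2ncccc2c1` gives 17000 nM
- compound 2 `COc1cc(NC(C)CCCNC(=O)NN)c2ncccc2c1` gives >= 250000 nM (a limit of the assay, not a number)
- compound 3 `COc1cc(NC(C)CCCNC(=O)NNC(=O)NCCO)c2ncccc2c1` gives 196000 nM

Compound 3 at 196000 nM holds the higher of the two true numbers, and the other belongs to compound 1 at 17000 nM. Compound 4 `COc1cc(NC(C)CCCNC(=O)Nc2ccc(Cl)c(C(F)(F)F)c2)c2ncccc2c1` carries 4-chloro-3-(trifluoromethyl)phenyl in place of ((2-hydroxyethyl)carbamoyl)amino on an amide-type nitrogen. The closest guide is compound 1, which carries the same aryl group, and the large step of a 12-fold higher number from compound 1 to compound 3 (1.06 log units; beyond the scatter) came from losing it. The step of an at least 1.2-fold lower number from compound 2 to compound 3 (0.10 log units; that floor lies within the scatter) says little here. A large step toward stronger inhibition is therefore expected (a 7.8-fold lower number from compound 3 to compound 4 (0.89 log units; beyond the scatter)) in this assay. Compound 4 is estimated at 25000 nM (expected range 6000 nM to 90000 nM).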

Compound 4, half-maximal inhibitory concentration: 3900 nM
Compound 4: middle estimate off by 6.4-fold (0.81 log units), on the high side; the measured number lies below the stated range.
By their numbers in this assay, from the lowest: compound 4; then compound 1; then compound 3. At a limit, above all of these: compound 2.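

Placing 4-chloro-3-(trifluoromethyl)phenyl on the amide-type nitrogen, in place of ((2-hydroxyethyl)carbamoyl)amino, gives a 50-fold lower number from compound 3 to compound 4 (1.70 log units; beyond the scatter) and shows that the aryl group does not need the longer link of compound 1, which gives 17000 nM against a lower number for compound 4. The same group in place of amino gives an at least 64-fold lower number from compound 2 to compound 4 (1.80 log units; beyond the scatter) and that step is only a floor. Compound 2 stands at a limit, not a number: the limit of >= 250000 nM in this assay, at which 1 of the 4 values shown sits.

On these data alone, whether the chlorine or the trifluoromethyl carries the gain stays open. So does whether a plain phenyl, a pyridine or a cyclohexyl ring on this nitrogen would keep it.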